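Swapping Fluoro for Chloro on an Aryl Ring

The compounds below may be only part of what the source reports. "The series", "measured", "known", "first", "only" and "open" are said of these compounds alone.

Measured compounds:
- compound 1 `Fc1ccc(C2=NN(c3ccccc3)C(c3ccc4ccccc4c3)C2)cc1`: 230 nM
- compound 2 `NC(=S)N1N=C(c2ccc(Br)cc2)CC1c1ccc2ccccc2c1`: 230 nM
- compound 3 `NC(=S)N1N=C(c2ccc(Cl)c(Cl)c2)CC1c1ccc2ccccc2c1`: 310 nM

All three numbers come from a functional assay on A549 cells (Homo sapiens) for antiproliferative activity, read by MTT assay, with a stated time of 24 h; on this read-out lower numbers stand for stronger inhibition of growth and higher numbers for weaker inhibition of growth. Compound 1 gives 230 nM and stands level with compound 2 at the digits shown; together they are the lowest of the three numbers, and the gap to compound 3 is within the scatter. Compound 4 `Clc1ccc(C2=NN(c3ccccc3)C(c3ccc4ccccc4c3)C2)cc1` has not yet been measured. It differs from compound 1 in one place: chloro in place of fluoro on an aromatic carbon, on an aromatic carbon of a six-membered aromatic ring of carbon only, para to a large group.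

Among the measured compounds shown here, only one measured step bears on a halogen swap on that ring: a 1.3-fold higher number from compound 2 to compound 3 (0.13 log units; within the scatter), a change that stayed within the scatter. That step sits on a different core, so it is a loose guide, but it is the only one here. On this basis the step in this assay is expected to stay within the scatter, with no clear direction, so compound 4 is estimated at 230 nM, with a range from 110 nM to 480 nM, meaning no change at the digits printed from compound 1 to compound 4 (within the scatter) is expected.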

Compound 4, concentration for 50% growth inhibition: 160 nM
Estimate against measurement, compound 4: 1.4-fold (0.16 log units) above; the measured number falls inside the stated range.
By their numbers in this assay, from the lowest: compounds 4, 1, 2 and 3 (each within the scatter of the next).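

In this assay, chloro in place of fluoro gives a 1.4-fold lower number from compound 1 to compound 4 (0.16 log units; within the scatter), so 4-fluorophenyl and 4-chlorophenyl cannot be told apart in this read-out. Among the compounds shown here, this is the first step taken directly on the core of compound 1, and it shows that this position holds either halogen with no shift beyond the scatter. Nothing available here speaks to why the two halogens read alike.

The compounds shown leave open how far this tolerance extends, as both groups compared here are single halogen atoms. Bromo on this same core, or a group of a different kind such as methoxy, an amine or a carboxylic acid at this position, could show whether growth inhibition depends on what sits here at all.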